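This account rests on a few compounds, and the source may have more. Where it says the series, first, only, none or still open, it means among the compounds named here.

Compound 1 `CCOC[C@H]1OC(n2c(Cl)nc3cc(Cl)c(Cl)cc32)[C@H](O)[C@@H]1O`: 80000 nM
Compound 2 `O[C@@H]1[C@@H](CCl)OC(n2c(Cl)nc3cc(Cl)c(Cl)cc32)[C@@H]1O`: 90000 nM
Compound 3 `O[C@@H]1[C@@H](CBr)OC(n2c(Cl)nc3cc(Cl)c(Cl)cc32)[C@@H]1O`: 90000 nM

These values come from a functional assay on KB cells (Homo sapiens) for inhibition; a higher number here means a weaker inhibitor, a lower number a stronger inhibitor. There compound 3 stands level with compound 2, and all three compounds lie within the scatter of one another. Compound 4 `[N-]=[N+]=NC[C@H]1OC(n2c(Cl)nc3cc(Cl)c(Cl)cc32)[C@H](O)[C@@H]1O` carries azido in place of bromo on a saturated chain carbon bound to a saturated ring carbon. Three measured steps at this place bear on it: a 1.1-fold higher number from compound 1 to compound 3 (0.05 log units; within the scatter), no change at the digits printed from compound 2 to compound 3 (within the scatter) and a 1.1-fold higher number from compound 1 to compound 2 (0.05 log units; within the scatter). All of them are within the scatter, but none involves azido, so the evidence is indirect. No step beyond the scatter is therefore expected in this assay, and no direction is favoured. The expected step is a 1.1-fold lower number from compound 3 to compound 4 (0.02 log units; within the scatter). The estimate for compound 4 is 85000 nM, with an expected range of 40000 nM to 160000 nM.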

Compound 4, half-maximal inhibitory concentration: 70000 nM
Beside the measured number, compound 4's estimate is 1.2-fold (0.08 log units) above it; measured number inside the range.
By their numbers in this assay, from the lowest: compounds 4, 1, 2 and 3 (each within the scatter of the next).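

In this assay, the change to azido gives a 1.3-fold lower number from compound 3 to compound 4 (0.11 log units; within the scatter) and a 1.3-fold lower number from compound 2 to compound 4 (0.11 log units; within the scatter) and also a 1.1-fold lower number from compound 1 to compound 4 (0.06 log units; within the scatter) on a saturated chain carbon bound to a saturated ring carbon. Azido, with three nitrogen atoms in place of a single halogen atom, thus joins ethoxy, chloro and bromo, and all four groups lie within the scatter of one another at this place. Nothing available accounts for this result. On these data alone, whether an amine, a carboxylic acid or a longer chain on this carbon would move the number beyond the scatter remains open. So does whether any group here can give a stronger inhibitor on the shared core.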